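The source may report more compounds than this note shows. Statements on the series, on what has been measured and on what is new or still open speak of the compounds shown alone.

Among the measured compounds shown here, in a functional assay on DU-145 cells (Homo sapiens) for inhibition, read by trypan blue exclusion, with a stated time of 96 h (on this read-out higher numbers stand for weaker inhibition of growth and lower numbers for stronger inhibition of growth), compound 3 `O=C(/C(=C\c1c[nH]c2ccccc12)Sc1ccc(Br)cc1)c1ccc(Br)cc1` gives 1000 nM, the lowest of the three numbers so far. Compound 1 `O=C(/C(=C\c1ccc(Cl)cc1)S(=O)(=O)c1ccc(Br)cc1)c1ccc(Br)cc1` gives 50000 nM and compound 2 `O=C(/C(=C\c1ccc(Br)c(O)c1)S(=O)(=O)c1ccc(Br)cc1)c1ccc(Br)cc1` gives 50000 nM, so both stand well above compound 3 on this assay. Compound 4 `O=C(/C(=C\c1c[nH]c2ccccc12)S(=O)(=O)c1ccc(Br)cc1)c1ccc(Br)cc1` has not yet been measured. The structural change is (4-bromophenyl)sulfonyl in place of (4-bromophenyl)sulfanyl on a double-bonded chain carbon bound to a carbonyl carbon and a double-bonded chain carbon.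

For the measured compounds named here, the only measured step, no change at the digits printed from compound 1 to compound 2 (within the scatter), lies elsewhere in the structure and does not test this swap. Going by the values given here, no measured pair shows the swap alone. The indirect evidence is that the entering (4-bromophenyl)sulfonyl group is already carried by compound 1, at 50000 nM, and by compound 2, at 50000 nM. Both also differ from compound 3 in another part of the structure, so they can only suggest a direction, not fix a size. A moderate rise in the number, meaning weaker inhibition of growth, is therefore expected, and the uncertainty is wide. The expected change is a 5.0-fold higher number from compound 3 to compound 4 (0.70 log units; beyond the scatter). Compound 4 is estimated at 5000 nM, with an expected range from 800 nM to 50000 nM.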

Compound 4, concentration for 50% growth inhibition: 25000 nM
Compound 4: the middle estimate sits 5.0-fold (0.70 log units) below what was measured, and the stated range covers the measured number.
By their numbers in this assay, from the lowest: compound 3; then compounds 4, 1 and 2 (each within the scatter of the next).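

In this assay, among the compounds shown here, (4-bromophenyl)sulfonyl in place of (4-bromophenyl)sulfanyl on a double-bonded chain carbon bound to a carbonyl carbon and a double-bonded chain carbon gives a 25-fold higher number from compound 3 to compound 4 (1.40 log units; beyond the scatter), a large step and the first reading of this swap on its own. With the sulfonyl group held in place, the other two steps give a 2.0-fold lower number from compound 1 to compound 4 (0.30 log units; within the scatter) and a 2.0-fold lower number from compound 2 to compound 4 (0.30 log units; within the scatter), so 1H-indol-3-yl is not separated from 4-chlorophenyl or from 4-bromo-3-hydroxyphenyl on this read-out. Among these compounds, the low number of compound 3 therefore goes with 1H-indol-3-yl and (4-bromophenyl)sulfanyl together, not with 1H-indol-3-yl alone.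

The compounds shown carry the (4-bromophenyl)sulfanyl group only with 1H-indol-3-yl, so whether the swap has a similar size with 4-chlorophenyl or 4-bromo-3-hydroxyphenyl remains open. They also leave open where a (4-bromophenyl)sulfinyl or a (4-bromophenyl)amino group at this place would fall relative to compound 3 and compound 4. No measurement given here accounts for the size of this step.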